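This account rests on a few compounds, and the source may have more. Where it says the series, first, only, none or still open, it means among the compounds named here.

Measured so far:
- compound 3, `COc1ccc(C2CC(Nc3nc4ccc(C)cc4s3)=NN2C(C)=O)cc1`: 39.4 umol/kg
- compound 1, `Cc1ccc2nc(NC(=O)/C=C/c3ccc(Cl)cc3)sc2c1`: "not determined" (no result reported)
- compound 2, `COc1ccc(/C=C/C(=O)Nc2nc3ccc(Cl)cc3s2)cc1O`: "not determined" (no result reported)

Going by the values given here, in a functional assay on the whole organism (strain albino) with Mus musculus as the target, with a stated time of 0.5 h (a higher number here means that more compound is needed for the effect, a lower number that less compound is needed), compound 3 gives 39.4 umol/kg, the only number the series offers. Among the compounds with values here, compound 1 gives "not determined" (no result reported) and compound 2 gives "not determined" (no result reported), so compound 3 stands alone, with nothing to rank it against, and no step between measured compounds can be read from the set.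

Compound 4 is `COc1ccc(C2CC(Nc3nc4ccc(C)cc4s3)=NN2C(C)=O)cc1O`. It differs from compound 3 by hydroxy in place of hydrogen on an aromatic carbon. The group that enters brings one hydrogen-bond donor and one hydrogen-bond acceptor and no ring; the rest of the structure is unchanged.

Within the data shown here, with no measured step for any change on the shared core, there is no basis for a directed expectation. The working assumption is that the step from compound 3 to compound 4 stays within the usual scatter, which is what the expected step of a 1.1-fold higher number from compound 3 to compound 4 (0.06 log units; within the scatter) in this assay means. Among the measured compounds shown here, for compound 4 the estimated dose for half-maximal effect is 45 umol/kg, with a range from 18 umol/kg to 110 umol/kg; the range is wide, as only one measured value anchors it.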

Compound 4, dose for half-maximal effect: 75.6 umol/kg
The estimate for compound 4 lay 1.7-fold (0.23 log units) below the measured number; the measured number falls inside the stated range.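

In this assay, going by these compounds alone, the exchange of 4-methoxyphenyl for 3-hydroxy-4-methoxyphenyl gives a 1.9-fold higher number from compound 3 to compound 4 (0.28 log units; within the scatter) and is the first step the series offers on the shared core. Hydroxy on this aromatic carbon, ortho to the methoxy group, therefore leaves the two compounds indistinguishable in this whole-organism read-out, so the position accepts this change without a resolved shift, while no step involving compound 1 or compound 2 can be read. No measurement at hand bears on what lies behind this result.

From the compounds shown here alone, whether an amine or a carboxylic acid on the same aromatic carbon would give a step beyond the scatter stays open. Also open, going by these compounds, is whether replacing the methoxy group itself, for example with a longer ether chain, would move the dose for half-maximal effect on this core.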